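A few compounds are considered here, and "the series" means these few. Any claim that something is new, unique, unknown or untested is made for them only; others in the source may bear on it.

Measured so far:
- compound 1, `NS(=O)(=O)c1ccc(N2C(=O)CC(CC(=O)c3ccccc3)C2=O)cc1`: 4230 nM
- compound 2, `O=C1CCCCC1C1CC(=O)N(Cc2ccccc2)C1=O`: 20000 nM

In an assay on Sf21 cells for inhibition of cytochrome c oxidase subunit 2 (Homo sapiens), read by spectrophotometry, with a stated time of 5 min (on this read-out higher numbers stand for weaker inhibition and lower numbers for stronger inhibition), compound 1 gives 4230 nM. This is the lowest of the two numbers available. Compound 2 gives 20000 nM, a higher number, and the gap between the two lies beyond the scatter of repeated measurements, so the two compounds are separated on this read-out. Among the measured compounds shown here, compound 2 shares no single point of difference with compound 1, so its value offers no step that can be carried over directly.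

The next compound, compound 3, `Cc1ccc(C(=O)CC2CC(=O)N(c3ccc(S(N)(=O)=O)cc3)C2=O)cc1`, is built on the core of compound 1 with one change: methyl in place of hydrogen on an aromatic carbon. For the measured compounds named here, no pair of measured compounds shows this change, so there is no measured step to lean on. A change of one carbon on an aromatic ring, far from the rest of the molecule, is in this setting expected to move the number little, if at all. For compound 3 the expected value is 3500 nM, with a range from 1200 nM to 10000 nM. That estimate amounts to a step of a 1.2-fold lower number from compound 1 to compound 3 (0.08 log units; within the scatter), expected to be none beyond the scatter.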

Compound 3, half-maximal inhibitory concentration: 980 nM
Estimate against measurement, compound 3: 3.6-fold (0.55 log units) above, and the stated range ends above it.
By their numbers in this assay, from the lowest: compound 3; then compound 1; then compound 2.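

In this assay, the outer ring of compound 1 turns out to be a place where even a very small change registers: going from phenyl to 4-methylphenyl gives a 4.3-fold lower number from compound 1 to compound 3 (0.64 log units; beyond the scatter), a modest step. The earlier compounds shown here could not show this, since compound 1 and compound 2 differ in more than one place and offered no single change to read. Here a single added carbon, bringing no ring, no hydrogen-bond donor or acceptor and no net charge, is enough to shift the number towards stronger inhibition, although nothing measured here explains how this comes about.

From the compounds shown here alone, this is one step at one position, so it remains open whether the shift belongs to methyl in particular or would appear with other groups at the same place, and whether it would carry over to a different core. An ethyl chain, a methoxy group, a chlorine atom or an amine on that ring carbon would each test this, as would the same methyl on another carbon of the ring.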